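This account rests on a few compounds, and the source may have more. Where it says the series, first, only, none or still open, it means among the compounds named here.

Compound 1 `O=C1C[C@H](OCc2cn(Cc3ccccc3)nn2)[C@H]2CO[C@@H]1O2` is the benzyl member of the series. In a functional assay on MDA-MB-231 cells (Homo sapiens) for cytotoxicity, read by MTT assay, with a stated time of 48 h (on this read-out lower numbers stand for stronger inhibition and higher numbers for weaker inhibition), compound 1 gives > 50000 nM, which is a limit of the assay and not a number. Compound 2 `O=C1C[C@H](OCc2cn(-c3ccc(F)cc3)nn2)[C@H]2CO[C@@H]1O2` carries a 4-fluorophenyl group on the aromatic nitrogen instead, and in this assay compound 2 gives 23700 nM. Among the measured compounds shown here, the only step measured so far is an at least 2.1-fold lower number from compound 1 to compound 2 (0.32 log units; beyond the scatter), and its size can be read only against (the limit of > 50000 nM in this assay, at which 1 of the 2 values shown sits), so it may be larger than it appears.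

Compound 3 `O=C1C[C@H](OCc2cn(-c3ccccc3Cl)nn2)[C@H]2CO[C@@H]1O2` is the next member, still to be measured in this assay. Its change from compound 1 is 2-chlorophenyl in place of benzyl on an aromatic nitrogen. For the measured compounds named here, the one relevant comparison is the move to an aryl group on that nitrogen in compound 2; on that basis a step of about the same kind is expected, an at least 2.0-fold lower number from compound 1 to compound 3 (0.30 log units; that floor lies within the scatter), with the measured limit leaving the true size open. Compound 3 is therefore estimated at 25000 nM, within 9000 nM to 70000 nM.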

Compound 3, half-maximal inhibitory concentration: 26400 nM
Estimate against measurement, compound 3: 1.1-fold (0.02 log units) below; the range from low to high includes it.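

Exchanging 4-fluorophenyl for 2-chlorophenyl on the aromatic nitrogen gives a 1.1-fold higher number from compound 2 to compound 3 (0.05 log units; within the scatter) in this assay, so these two aryl groups cannot be told apart at this position. Against benzyl, 2-chlorophenyl gives an at least 1.8-fold lower number from compound 1 to compound 3 (0.27 log units; that floor lies within the scatter), so this step alone does not establish a gain over benzyl. The true size of the steps from benzyl stays open: the limit of > 50000 nM in this assay, at which 1 of the 3 values shown sits.

As far as these compounds go, what an unsubstituted phenyl group or a 4-carboxyphenyl group would give on this nitrogen remains open, and so does whether a halogen plays any part in the readings of compound 2 and compound 3. Also open, from the compounds shown here alone, is whether an aminoalkyl chain on this nitrogen would give a reading clearly different from those of the two aryl compounds.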